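A few compounds are considered here, and "the series" means these few. Any claim that something is new, unique, unknown or untested is made for them only; others in the source may bear on it.

In a functional assay (trachea) with Cavia porcellus as the target (a higher number here means that more compound is needed for the effect, a lower number that less compound is needed), three related compounds have been measured so far. Compound 1 (`CCCn1c(=O)n(CCC(=O)O)c(=O)c2[nH]cnc21`) gives 21200 nM, compound 2 (`CCCn1c(=O)n(CCCOC)c(=O)c2[nH]cnc21`) gives 2900 nM, and compound 3 (`C=CCCn1cnc2c1c(=O)n(C)c(=O)n2CCC`) gives 16800 nM. Compound 3 is therefore level with compound 1 within the scatter, while its number is clearly higher than that of compound 2.

Compound 4 (`CCCn1c(=O)n(C)c(=O)c2c1ncn2CCCO`) differs from compound 3 by a single change: hydroxymethyl in place of vinyl on a saturated chain carbon, two bonds along the chain from an aromatic nitrogen.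

Going by the values given here, no measured step makes this exact exchange. The closest guide is a 7.3-fold lower number from compound 1 to compound 2 (0.86 log units; beyond the scatter), a modest step in which methoxymethyl takes the place of carboxy at a place described in the same words. Since it swaps different groups, it is only a loose guide. A modest step towards a lower number is therefore expected in this assay, although a step within the scatter remains possible.

The estimated step is a 2.1-fold lower number from compound 3 to compound 4 (0.32 log units; beyond the scatter). For compound 4, the estimated value is 8000 nM, with an expected range from 2500 nM to 25000 nM.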

Compound 4, half-maximal effective concentration: 22600 nM
Estimate against measurement, compound 4: 2.8-fold (0.45 log units) below; measured number inside the range.
By their numbers in this assay, from the lowest: compound 2; then compounds 3, 1 and 4 (each within the scatter of the next).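

In this assay, hydroxymethyl in place of vinyl at this place on the chain gives a 1.3-fold higher number from compound 3 to compound 4 (0.13 log units; within the scatter) and so, within the scatter, the but-3-en-1-yl and 3-hydroxypropyl chains cannot be told apart here. The entering group brings a hydrogen-bond donor and a hydrogen-bond acceptor where vinyl has neither, yet in this single pair that difference comes with no step beyond the scatter. Nothing available explains why the two compounds read alike.

From the compounds shown here alone, whether an amine in place of the hydroxymethyl, or a longer chain, would shift the number beyond the scatter remains open. Also open, going by these compounds, is whether methoxymethyl, which compound 2 carries on its chain, would give a lower number on the chain of compound 4.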